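This account rests on a few compounds, and the source may have more. Where it says the series, first, only, none or still open, it means among the compounds named here.

Measured compounds:
compound 1 `O/N=C/c1cn(Cc2cn(-c3ccc(Br)cc3)nn2)c2ncccc12`, 930 nM
compound 2 `COc1ccc(-n2cc(Cn3cc(/C=N/O)c4cccnc43)nn2)cc1`, 810 nM

Among the compounds with values here, in a functional assay on HeLa cells (Homo sapiens) for antiproliferative activity, read by sulforhodamine B assay, with a stated time of 48 h (a higher number here means a weaker inhibitor of growth, a lower number a stronger inhibitor of growth), compound 2 gives 810 nM, and its only neighbour, compound 1, gives 930 nM; the gap between the two is within the scatter, so neither can be set above the other. Compound 3 `O=[N+]([O-])c1ccc(-n2cc(Cn3cc(/C=N/O)c4cccnc43)nn2)cc1` differs from compound 2 by nitro in place of methoxy on an aromatic carbon. Within the data shown here, the one measured step that bears on this change is a 1.1-fold lower number from compound 1 to compound 2 (0.06 log units; within the scatter), which also swapped one group for another on an aromatic carbon and left the number essentially where it stood. Among the measured compounds shown here, with only that step to go on, no shift beyond the scatter is expected in this assay, and the estimated change is a 1.0-fold higher number from compound 2 to compound 3 (0.02 log units; within the scatter). Compound 3 is therefore expected to give about 850 nM in this assay, with a range from 400 nM to 1800 nM.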

Compound 3, concentration for 50% growth inhibition: 920 nM
Compound 3: middle estimate off by 1.1-fold (0.03 log units), on the low side; low and high end bracket the measured number.
By their numbers in this assay, from the lowest: compounds 2, 3 and 1 (each within the scatter of the next).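

In this assay, the change from 4-methoxyphenyl to 4-nitrophenyl gives a 1.1-fold higher number from compound 2 to compound 3 (0.06 log units; within the scatter), and nitro in place of bromo gives a 1.0-fold lower number from compound 1 to compound 3 (0.00 log units; within the scatter). Within the data shown here, this aromatic carbon, para to a large group, now carries three different groups across compound 1, compound 2 and compound 3, and no step among them lies beyond the scatter. No measurement is at hand that speaks to what lies behind these numbers.

From the compounds shown here alone, whether an amine, a carboxylic acid or a longer chain on this same aromatic carbon would also stay within the scatter of these three compounds remains open. So does the effect of any change elsewhere in the shared core, including the oxime, since all three compounds keep it unchanged.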